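Diethylamino in Place of Isopropylamino: An Expected Flat Step

The source may report more compounds than this note shows. Statements on the series, on what has been measured and on what is new or still open speak of the compounds shown alone.

In a functional assay for inhibition, with Homo sapiens as the target (a lower number here means that less compound is needed, a higher number that more compound is needed for the effect), compound 1 `CCCCC(=O)Nc1ccc(C2=NNC(=O)CC2)cc1` gives 2.64 ug/mL, and compound 2 `CCCNCC(=O)Nc1ccc(C2=NNC(=O)CC2)cc1` gives about 46.4 ug/mL. Compound 3 `CC(C)NCC(=O)Nc1ccc(C2=NNC(=O)CC2)cc1` gives about 46.4 ug/mL, level with compound 2 at the digits reported, and these two share the highest number of the three. Compound 4 `CCN(CC)CC(=O)Nc1ccc(C2=NNC(=O)CC2)cc1` has not yet been measured. It differs from compound 3 by diethylamino in place of isopropylamino on a saturated chain carbon bound to a carbonyl carbon, with diethylamino in place of isopropylamino on a saturated chain carbon bound to a carbonyl carbon.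

Among the compounds with values here, the closest precedent is no change at the digits printed from compound 2 to compound 3 (within the scatter), a change of isopropyl in place of propyl on an amine nitrogen, which stayed within the scatter. The large steps of an 18-fold higher number from compound 1 to compound 2 (1.24 log units; beyond the scatter) and an 18-fold higher number from compound 1 to compound 3 (1.24 log units; beyond the scatter) bear on it less, since each of them introduces the amine nitrogen, which compound 4 retains. No step beyond the scatter is therefore expected in this assay, in either direction. The expected step is a 1.2-fold lower number from compound 3 to compound 4 (0.06 log units; within the scatter). For compound 4 the estimated value is 40 ug/mL, with an expected range of 15 ug/mL to 100 ug/mL.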

Compound 4, half-maximal effective concentration: about 10 ug/mL
Beside the measured number, compound 4's estimate is 4.0-fold (0.60 log units) above it, and the stated range ends above it.
By their numbers in this assay, from the lowest: compound 1; then compound 4; then compounds 2 and 3 (each within the scatter of the next).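

In this assay the place on a saturated chain carbon bound to a carbonyl carbon turns out to respond to the choice of amine, since diethylamino gives a 4.6-fold lower number from compound 3 to compound 4 (0.67 log units; beyond the scatter) and a 4.6-fold lower number from compound 2 to compound 4 (0.67 log units; beyond the scatter) while the earlier change from propyl to isopropyl on the amine nitrogen stayed within the scatter. An amine at this place therefore does not fix the number at the level shared by compound 2 and compound 3, although diethylamino still leaves a 3.8-fold higher number from compound 1 to compound 4 (0.58 log units; beyond the scatter) against the propyl group. Nothing available explains why diethylamino differs from the other two amines.

Going by these compounds, it remains open whether dimethylamino would follow diethylamino or sit with propylamino and isopropylamino. The same question stands for a ring amine such as piperidine or morpholine at this place.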